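The source may hold more compounds than are shown below. What is called first, only, known or untested is meant among the compounds shown, and "the series" means these compounds.

In a functional assay on MDA-MB-231 cells (Homo sapiens) for inhibition, read by sulforhodamine B assay, with a stated time of 48 h, tested at 10 uM (on this read-out lower numbers stand for less inhibition and higher numbers for more inhibition at the one concentration tested (going by the name of the read-out)), compound 1 `Fc1ccc(-c2cn3ccnc3c(-c3ccc4ncn(C5CCCCC5)c4c3)n2)cc1` gives 15.8%, and compound 2 `Clc1ccc(-c2cn3ccnc3c(-c3ccc4ncn(C5CCCCC5)c4c3)n2)cc1` gives 15.3%. Compound 2 stands lowest of the two numbers, with compound 1 nearest, and the step of a number 0.5 percentage points lower from compound 1 to compound 2 (within the scatter) lies within the scatter. Compound 3 `c1csc(-c2cn3ccnc3c(-c3ccc4ncn(C5CCCCC5)c4c3)n2)c1` differs from compound 2 by thiophen-2-yl in place of 4-chlorophenyl on an aromatic carbon. Among the compounds with values here, the single measured step exchanges chloro for fluoro only and says little about replacing the whole ring, so the expectation is a step of a number 0.3 percentage points lower from compound 2 to compound 3 (within the scatter) with no size beyond the scatter. Compound 3 is therefore expected to give 15%, within a range from 4% to 30%.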

Compound 3, a percentage reported as inhibition, at one concentration (the size of the read-out at that concentration, not a potency): 10.8%
Beside the measured number, compound 3's estimate is 4.2 percentage points above it, and the stated range covers the measured number.
By their numbers in this assay, from the lowest: compounds 3, 2 and 1 (each within the scatter of the next).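

Swapping the whole ring at this position, not just its halogen, gives a number 4.5 percentage points lower from compound 2 to compound 3 (within the scatter) in this assay, and a number 5 percentage points lower from compound 1 to compound 3 (within the scatter), so here thiophen-2-yl, a five-membered ring with a sulfur atom, takes the place of 4-chlorophenyl or 4-fluorophenyl with no step beyond the scatter. Nothing available explains these numbers. Still open, as far as these compounds go, is whether a group of a different kind at this position, such as an amine or a carboxylic acid, would give a step beyond the scatter.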